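A few compounds are considered here, and "the series" means these few. Any claim that something is new, unique, unknown or untested is made for them only; others in the source may bear on it.

Among the measured compounds shown here, compound 2, `COc1ccc(/C=C/C(=O)c2cccc(-c3cccc(F)c3)c2)cc1OC`, is the stronger of the two compounds measured so far: in a functional assay on SW480 cells (Homo sapiens) for cytotoxicity, read by sulforhodamine B assay, with a stated time of 48 h (a lower number here means a stronger inhibitor, a higher number a weaker inhibitor), compound 2 gives 2970 nM. For the measured compounds named here, the only other measured compound, compound 1, `COc1ccc(/C=C/C(=O)c2ccc(N)c(-c3ccc(F)cc3)c2)cc1OC`, differs from it in more than one place, so the two values can only be set side by side; in this assay compound 1 gives 6640 nM, the higher number of the pair.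

Compound 3, `COc1ccc(/C=C/C(=O)c2cccc(-c3ccc(F)cc3)c2)cc1OC`, has not yet been measured. It differs from compound 2 in a single place: 4-fluorophenyl in place of 3-fluorophenyl on an aromatic carbon. Going by the values given here, nothing among the measured compounds isolates this change, so no measured step can guide the expectation directly. Moving the fluorine within the same pendant ring keeps the atoms and their count unchanged, and a step no larger than the usual scatter is expected, in either direction. The step of a 1.0-fold higher number from compound 2 to compound 3 (0.00 log units; within the scatter) is the estimate for compound 3. Compound 3 is expected to give about 3000 nM in this assay, somewhere between 1200 nM and 7500 nM.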

Compound 3, half-maximal inhibitory concentration: 6490 nM
For compound 3 the middle estimate is 2.2-fold (0.34 log units) below the measured one, within the range that was stated.
By their numbers in this assay, from the lowest: compound 2; then compounds 3 and 1 (each within the scatter of the next).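

Compound 2 and compound 3 have the same atoms, yet in this assay 4-fluorophenyl in place of 3-fluorophenyl, meta to a large group, gives a 2.2-fold higher number from compound 2 to compound 3 (0.34 log units; beyond the scatter) and so shows that the place of the fluorine on this ring alone can shift the value beyond the scatter. Among the compounds shown here, compound 3 also allows the first single-place reading of the amino group: hydrogen in place of amino on an aromatic carbon gives a 1.0-fold lower number from compound 1 to compound 3 (0.01 log units; within the scatter) with 4-fluorophenyl present, so that change makes no difference beyond the scatter here. The data at hand offer no explanation for the fluorine step.

On these data alone, whether the amino group would count as little alongside 3-fluorophenyl remains open. Also open, as far as these compounds go, is how a plain phenyl, a chlorophenyl or a methoxyphenyl group would compare at this place.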